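Thiophene ester amide in place of bromotolyl amide: cytotoxicity

This account rests on a few compounds, and the source may have more. Where it says the series, first, only, none or still open, it means among the compounds named here.

Compound 1 `O=C(CSc1snnc1-c1ccc(Br)cc1Br)Nc1ccccc1F`: in an ADME assay on MT4 cells (Homo sapiens) for cytotoxicity, read by MTT assay, with a stated time of 5 days (on this read-out lower numbers stand for higher toxicity in this test and higher numbers for lower toxicity in this test), compound 1 gives >= 27800 nM, which is a limit of the assay and not a number.
Compound 2 `Cc1ccc(NC(=O)CSc2snnc2-c2ccc(Br)cc2Br)c(Br)c1`: in this assay compound 2 gives > 216000 nM, which is also a limit of the assay and not a number.

Compound 2 thus stands at the limit of > 216000 nM in this assay, at which 1 of the 2 values shown sits, and no number for it is known. Within the data shown here, the only measured step, a step that the two limits leave unreadable from compound 1 to compound 2, cannot be read, as both ends sit at limits; compound 1 sits at the limit of >= 27800 nM in this assay, at which 1 of the 2 values shown sits.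

Compound 3 `COC(=O)c1ccsc1NC(=O)CSc1snnc1-c1ccc(Br)cc1Br` differs from compound 2 by 3-(methoxycarbonyl)thiophen-2-yl in place of 2-bromo-4-methylphenyl on an amide-type nitrogen. No readable measured step bears on this change, so no size or direction beyond the scatter can be derived for it. Both measured compounds sit at limits, and compound 3 is expected to behave alike, with an expected step of an at least 1.4-fold lower number from compound 2 to compound 3 (0.15 log units; that floor lies within the scatter) from compound 2. For compound 3 the estimate in this assay is 150000 nM, expected to fall between 30000 nM and 400000 nM, most likely again reported only as a limit.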

Compound 3, half-maximal cytotoxic concentration: > 227000 nM
Compound 3: a limit, no number (the forecaster's own chance of this, stated with the estimate: 65%); middle value at least 1.5-fold (0.17 log units) from the limit.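

In this assay compound 3 gives > 227000 nM, which is a limit of the assay and not a number. The steps to compound 3 from compound 1 and compound 2 therefore cannot be read. The compounds shown leave open whether the group on the amide-type nitrogen changes cytotoxicity at all.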